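Chloro in Place of Methoxy on Two Cores

This account rests on a few compounds, and the source may have more. Where it says the series, first, only, none or still open, it means among the compounds named here.

Compound 1 `Clc1ccccc1C1CCc2nc[nH]c2C1` gives 3.1 in a physicochemical assay for lipophilicity, at pH 7.4; a lower number here means a more polar compound, a higher number a more lipophilic compound.
Compound 2 `COc1ccccc1C1CCc2nc[nH]c2C1` gives 2.8 in this assay.
Compound 3 `COc1ccccc1C1Cc2nccn2C1` gives 1.9 in this assay.

Compound 1 and compound 2 share one core, while compound 3 is built on another; the difference between the two cores is not broken down here. Compound 3 stands lowest of the three, and its distance to compound 2 and to compound 1 is beyond the scatter in both cases.

Between compound 2 and compound 1 a single change was made: chloro in place of methoxy on an aromatic carbon. The step was a number 0.30 log units higher from compound 2 to compound 1 (within the scatter).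

Compound 4 `Clc1ccccc1C1Cc2nccn2C1` has not yet been measured in this assay. It stands to compound 3 as compound 1 stands to compound 2: chloro in place of methoxy on an aromatic carbon. The two places are not identical word for word: in compound 2 the site is ortho to a group of 9 heavy atoms, in compound 3 it is ortho to a group of 8 heavy atoms, so this is the same kind of change, not the same change. Among the compounds shown it occurs twice in all.

The expectation for compound 4 rests on compound 2 and compound 1, whose step was a number 0.30 log units higher from compound 2 to compound 1 (within the scatter), and on that basis the expected step is a number 0.30 log units higher from compound 3 to compound 4 (within the scatter), within the scatter. Compound 4 is therefore estimated at 2.2 in this assay, expected to fall between 1.8 and 2.6.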

Compound 4, distribution coefficient: 2.6
Beside the measured number, compound 4's estimate is 0.40 log units below it, within the range that was stated.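

In this assay the new pair shows a number 0.70 log units higher from compound 3 to compound 4 (beyond the scatter) for chloro in place of methoxy on an aromatic carbon, while the pair on the other core shows a number 0.30 log units higher from compound 2 to compound 1 (within the scatter) for the same kind of change. This shows that the size of the step read on one core did not fix its size on the other, since only the new step lies beyond the scatter, but two pairs are too few to establish a typical size for this change across the series or to say how far each core governs it. Nothing measured here accounts for the difference in outcome between the two cores.

The compounds shown leave open how other groups on this aromatic carbon, such as an amine, a carboxylic acid or a longer chain, would compare with chloro and methoxy on either core. They also leave open whether chloro in place of methoxy would give a similar step on a third core, or at another carbon of the six-membered aromatic ring.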